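Acetal in place of the lactam on the sulfur-bound chain

The source may hold more compounds than are shown below. What is called first, only, known or untested is meant among the compounds shown, and "the series" means these compounds.

Three compounds share one core and differ only in the group carried on a saturated chain carbon bound to a sulfur. Compound 1 `CO[C@H]1C[C@H](O)C[C@@H](CSc2nc(-c3ccccc3)c(-c3ccccc3)[nH]2)O1` gives 90 nM in an assay on microsomes from liver for inhibition of sterol O-acyltransferase 1 (Rattus norvegicus); a higher number here means a weaker inhibitor, a lower number a stronger inhibitor. Compound 2 `O=C1CCCC(CSc2nc(-c3ccccc3)c(-c3ccccc3)[nH]2)O1` gives 740 nM in that assay, and compound 3 `O=C1CCC(CSc2nc(-c3ccccc3)c(-c3ccccc3)[nH]2)N1` gives 360 nM. Compound 3 thus stands second highest of the three numbers: the step of a 4.0-fold higher number from compound 1 to compound 3 (0.60 log units; beyond the scatter) puts it well behind compound 1, while the step of a 2.1-fold lower number from compound 2 to compound 3 (0.31 log units; beyond the scatter) places it a little ahead of compound 2.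

Compound 4 `COC(CSc1nc(-c2ccccc2)c(-c2ccccc2)[nH]1)OC` has not yet been measured. It differs from compound 3 in one place: dimethoxymethyl in place of 5-oxopyrrolidin-2-yl on a saturated chain carbon bound to a sulfur. For the measured compounds named here, none of the measured steps is this change, but all three bear on it, since each swaps the group at the same position. Those steps ran from an 8.2-fold higher number from compound 1 to compound 2 (0.91 log units; beyond the scatter) down to a 2.1-fold lower number from compound 2 to compound 3 (0.31 log units; beyond the scatter), so exchanges of this group have moved the number by modest amounts in either direction. The acetal that enters is acyclic and carries no donor, unlike the lactam that leaves. He therefore expects a modest step, most likely toward a higher number, as the step of a 1.8-fold higher number from compound 3 to compound 4 (0.26 log units; within the scatter) expresses. His estimate for compound 4 in this assay is 650 nM, within a range of 200 nM to 2100 nM.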

Compound 4, half-maximal inhibitory concentration: 580 nM
Beside the measured number, compound 4's estimate is 1.1-fold (0.05 log units) above it; measured number inside the range.
By their numbers in this assay, from the lowest: compound 1; then compounds 3, 4 and 2 (each within the scatter of the next, the first and the last beyond it).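

The steps of a 1.6-fold higher number from compound 3 to compound 4 (0.21 log units; within the scatter) and a 1.3-fold lower number from compound 2 to compound 4 (0.11 log units; within the scatter) show that in this assay dimethoxymethyl, with no ring and no hydrogen-bond donor, cannot be told apart from the ring groups of compound 3 and compound 2. At this place, on a saturated chain carbon bound to a sulfur, neither the ring nor the donor of 5-oxopyrrolidin-2-yl is therefore shown to be needed to hold a number of this size, since the open acetal, which has neither, stays within the scatter of that lactam. Compound 1 alone stands apart, with a 6.4-fold higher number from compound 1 to compound 4 (0.81 log units; beyond the scatter) marking a gap beyond the scatter, and no evidence at hand accounts for any of these numbers.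

The compounds shown leave open which feature of the ring group of compound 1 goes with its lower number, as a ring acetal carrying only the methoxy group or only the hydroxyl group would be needed to separate them. They also leave open how an amine, a carboxylic acid or a longer chain at this place would read in this assay.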